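Swapping Thiophenyl for Methyl on the Shared Core

The source may hold more compounds than are shown below. What is called first, only, known or untested is meant among the compounds shown, and "the series" means these compounds.

For the measured compounds named here, compound 3 `Cc1c(C(C)OC(=O)Nc2ccccc2)oc2nc(-c3cccs3)nn12` gives 7.94 nM in a functional assay on CHO cells for antagonist activity at metabotropic glutamate receptor 5 (Homo sapiens), read by calcium flux (a higher number here means a weaker inhibitor, a lower number a stronger inhibitor), the lowest of the three numbers measured so far. Compound 2 `Cc1c(C(C)OC(=O)Nc2ccccc2)oc2nc(Cl)nn12` gives 10 nM, and a 1.3-fold lower number from compound 2 to compound 3 (0.10 log units; within the scatter). Compound 1 `Cc1c(C(C)OC(=O)Nc2ccccc2)oc2ncnn12` gives 63.1 nM.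

Compound 4 `Cc1nc2oc(C(C)OC(=O)Nc3ccccc3)c(C)n2n1` differs from compound 3 by methyl in place of thiophen-2-yl on an aromatic carbon. Going by the values given here, two measured steps bear on this position: a 7.9-fold lower number from compound 1 to compound 3 (0.90 log units; beyond the scatter) and a 6.3-fold lower number from compound 1 to compound 2 (0.80 log units; beyond the scatter). Both show that a group in place of hydrogen here lowers the number, the one-atom chloro almost as much as the thiophen-2-yl. Methyl is likewise a single heavy atom, so a modest rise from compound 3 is expected, probably not back to the level of compound 1. Compound 4 is therefore expected to give about 20 nM, between 7 nM and 60 nM. The estimate implies a 2.5-fold higher number from compound 3 to compound 4 (0.40 log units; beyond the scatter).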

Compound 4, half-maximal inhibitory concentration: 39.8 nM
For compound 4 the middle estimate is 2.0-fold (0.30 log units) below the measured one; the range from low to high includes it.
By their numbers in this assay, from the lowest: compounds 3 and 2 (each within the scatter of the next); then compounds 4 and 1 (each within the scatter of the next).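

Methyl, though a single heavy atom like chloro, does not match chloro at this position (a 4.0-fold higher number from compound 2 to compound 4 (0.60 log units; beyond the scatter)), and it also falls short of thiophen-2-yl (a 5.0-fold higher number from compound 3 to compound 4 (0.70 log units; beyond the scatter)). Against hydrogen, methyl shows no change beyond the scatter (a 1.6-fold lower number from compound 1 to compound 4 (0.20 log units; within the scatter)), so the lowering seen with chloro and thiophen-2-yl does not extend to every group placed here. Nothing available explains this difference between the groups. The compounds shown leave open how an amine, a methoxy group or a longer chain such as propyl would fare at this position.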